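From a dihydroxyazepane to a hydroxyethylazepane on the sulfonyl

The source may hold more compounds than are shown below. What is called first, only, known or untested is meant among the compounds shown, and "the series" means these compounds.

Within the data shown here, compound 1 `O=C(Nc1ccc(F)c(Cl)c1)c1ccc(F)c(S(=O)(=O)N2C[C@H](O)CC[C@H](O)C2)c1` gives 25500 nM in an ADME assay on HepG2 2.2.15 cells (Homo sapiens) for cytotoxicity, read by luminescence, with a stated time of 3 days (a lower number here means that less compound is tolerated, a higher number that more compound is tolerated), the higher of the two numbers known so far. Compound 2 `O=C(Nc1ccc(F)c(Cl)c1)c1ccc(F)c(S(=O)(=O)N2CCCCC(CO)C2)c1` gives 3100 nM in this assay, and that single change produced an 8.2-fold lower number from compound 1 to compound 2 (0.92 log units; beyond the scatter). Compound 3 `CC(O)C1CCCCN(S(=O)(=O)c2cc(C(=O)Nc3ccc(F)c(Cl)c3)ccc2F)C1` differs from compound 1 by 3-(1-hydroxyethyl)azepan-1-yl in place of 3,6-dihydroxyazepan-1-yl on a sulfonyl sulfur. As in compound 2, a single hydroxyl replaces the two of compound 1, so a drop of comparable size is expected because of an 8.2-fold lower number from compound 1 to compound 2 (0.92 log units; beyond the scatter). Compound 3 is therefore estimated at 3500 nM in this assay, within 1200 nM to 11000 nM, which would mean a 7.3-fold lower number from compound 1 to compound 3 (0.86 log units; beyond the scatter).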

Compound 3, half-maximal cytotoxic concentration: 2600 nM
The estimate for compound 3 lay 1.3-fold (0.13 log units) above the measured number; low and high end bracket the measured number.
By their numbers in this assay, from the lowest: compounds 3 and 2 (each within the scatter of the next); then compound 1.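

In this assay, 3-(1-hydroxyethyl)azepan-1-yl on the sulfonyl sulfur gives a 9.8-fold lower number from compound 1 to compound 3 (0.99 log units; beyond the scatter), so a second azepane carrying its hydroxyl on a side chain also falls well short of the 3,6-dihydroxyazepan-1-yl group. Methyl in place of hydrogen on the chain carbon bound to the oxygen does not separate the two side-chain compounds, with a 1.2-fold lower number from compound 2 to compound 3 (0.08 log units; within the scatter). No evidence is available to explain either step. The compounds shown leave open how a hydroxyl placed directly on the azepane ring would compare with these side chains, and how an amine or a carboxylic acid on the side chain would read in this assay.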